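Pyrazine amide series: aminoethoxy extension of compound 2

The source may report more compounds than this note shows. Statements on the series, on what has been measured and on what is new or still open speak of the compounds shown alone.

Three amides on a shared core have numbers in a functional assay on BXPC-3 cells (Homo sapiens) for inhibition, read by MTT assay, with a stated time of 72 h; a higher number here means a weaker inhibitor, a lower number a stronger inhibitor. Compound 1 `COc1cc(NC(=O)c2cnc(C)cn2)c2ncccc2c1` gives 6700 nM. Compound 2 `COc1cc(NC(=O)c2cnccn2)c2ncccc2c1` gives 470 nM, the lowest of the two numbers shown, with compound 1 as its nearest neighbour after a step of a 14-fold lower number from compound 1 to compound 2 (1.15 log units; beyond the scatter). For compound 3 `COc1cc(NC(=O)c2ncccn2)c2ncccc2c1` the assay reports only the limit > 10000 nM and no number. The step of an at least 21-fold higher number from compound 2 to compound 3 (1.32 log units; beyond the scatter) is large, while the step of an at least 1.4-fold higher number from compound 1 to compound 3 (0.17 log units; that floor lies within the scatter) has a floor that lies within the scatter; both rest on the same floor (the limit of > 10000 nM in this assay, at which 1 of the 3 values shown sits).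

Compound 4 `NCCOc1cc(NC(=O)c2cnccn2)c2ncccc2c1` is not yet measured. It differs from compound 2 by aminomethyl in place of hydrogen on a saturated chain carbon bound to an oxygen on an aromatic ring. Among the measured compounds shown here, none of the measured steps touches this part of the molecule: the steps from compound 1 to compound 2 and from compound 2 to compound 3 all change the amide aryl group or its methyl. For the measured compounds named here, no measured step therefore bears directly on the change to compound 4, and no step beyond the scatter is expected in either direction. Compound 4 is estimated at 700 nM, between 200 nM and 3000 nM, which means an expected step of a 1.5-fold higher number from compound 2 to compound 4 (0.17 log units; within the scatter).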

Compound 4, half-maximal inhibitory concentration: > 10000 nM
Compound 4 was reported as a limit (the forecaster's own chance of this, stated with the estimate: 8%); middle value at least 14-fold (1.15 log units) from the limit.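

In this assay, among the compounds shown here, this position is not neutral, although the earlier steps, all on the amide aryl group or its methyl, could not show that: the change from methoxy to 2-aminoethoxy gives an at least 21-fold higher number from compound 2 to compound 4 (1.32 log units; beyond the scatter). The value of compound 4, > 10000 nM, is a limit and not a number. The step is therefore a floor, so a change on the chain bound to the oxygen can, like the amide change to pyrimidin-2-yl in compound 3, take a compound from a measurable number to the same limit: the limit of > 10000 nM in this assay, at which 2 of the 4 values shown sit.

The compounds shown do not tell whether the terminal amine or the longer chain carries this step; an ethoxy or a 2-hydroxyethoxy group in place of methoxy would separate the two, and a dimethylamino group or a carboxylic acid at the chain end would test whether the amine itself matters. Also open, from the compounds shown here alone, is whether the result holds with other amide groups, as the 2-aminoethoxy group appears here only with the pyrazin-2-yl amide.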